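Swapping the Aryl Group on a Shared Core

The source may hold more compounds than are shown below. What is called first, only, known or untested is meant among the compounds shown, and "the series" means these compounds.

Compound 1, `CCOC(=O)CN(Cc1ccccc1)c1nc(Nc2ccc(Cl)cc2)ncc1[N+](=O)[O-]`: in a functional assay on A549 cells (Homo sapiens) for antiproliferative activity, read by MTT assay, with a stated time of 48 h (on this read-out higher numbers stand for weaker inhibition and lower numbers for stronger inhibition), compound 1 gives > 100000 nM, which is a limit of the assay, not a number.
Compound 2, `CCOC(=O)CNc1nc(Nc2ccc(Cl)cc2)ncc1[N+](=O)[O-]`: in this assay compound 2 gives > 100000 nM, again a limit of the assay.

Both measured values are limits, so compound 1 stands at the edge of what this assay can report rather than at a number. Going by the values given here, the only measured step, a step that the two limits leave unreadable from compound 1 to compound 2, concerns hydrogen in place of benzyl on a nitrogen on an aromatic ring and cannot be read. Compound 3, `CCOC(=O)CN(Cc1ccccc1)c1nc(Nc2cccc(OC)c2)ncc1[N+](=O)[O-]`, differs from compound 1 by 3-methoxyphenyl in place of 4-chlorophenyl on a nitrogen on an aromatic ring. No measured step touches this part of the molecule, so nothing shown speaks directly to it. What is shown is the limit of > 100000 nM in this assay, at which 2 of the 2 values shown sit, and it gives no reason to expect compound 3 to fall anywhere else. The expected step is a number no higher from compound 1 to compound 3 (the limit leaves the size open). Compound 3 is therefore estimated at 100000 nM, with a likely range from 30000 nM to 300000 nM, and most probably once more only a limit.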

Compound 3, half-maximal inhibitory concentration: > 100000 nM
Compound 3 was reported as a limit (the forecaster's own chance of this, stated with the estimate: 75%); the middle value sits exactly at the limit.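

Compound 1 and compound 3 both stop at a limit of the assay, so the step between them cannot be read: the limit of > 100000 nM in this assay, at which 3 of the 3 values shown sit.

Still open, on these data alone, is whether 3-methoxyphenyl and 4-chlorophenyl differ at all in this assay and which change to the shared core would give a readable number.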